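Cyclohexyl for Oxanyl Across Two Cores

This account rests on a few compounds, and the source may have more. Where it says the series, first, only, none or still open, it means among the compounds named here.

Compound 1 `c1ccc2c(c1)CN[C@@H](CN(Cc1ccc(CNC3CCOCC3)cc1)[C@H]1CCCc3cccnc31)C2` and compound 2 `CC1(C)CCC(NCc2ccc(CN(C[C@H]3Cc4ccccc4CN3)[C@H]3CCCc4cccnc43)cc2)CC1` differ in a single place: 4,4-dimethylcyclohexyl in place of oxan-4-yl on an amine nitrogen. In a functional assay on cells for agonist activity at C-X-C chemokine receptor type 4 (Homo sapiens), read by fluorescence and calcium flux, with a stated time of 90 s (on this read-out higher numbers stand for an effect only at larger amounts of compound and lower numbers for an effect already at smaller amounts), compound 1 gives only the limit > 30000 nM, a ceiling of the assay rather than a number. Compound 2 likewise returns only the limit > 30000 nM. The step that the two limits leave unreadable from compound 1 to compound 2 therefore cannot be sized. Compound 3 `C(=C/CN(C[C@H]1Cc2ccccc2CN1)[C@H]1CCCc2cccnc21)\CNC1CCOCC1` carries a different core from compound 1; the difference between the two cores is not broken down here. In this assay compound 3 also reaches only the limit > 30000 nM. Compound 4 `CC1(C)CCC(NC/C=C/CN(C[C@H]2Cc3ccccc3CN2)[C@H]2CCCc3cccnc32)CC1`, not yet measured, repeats the same change on the core of compound 3: 4,4-dimethylcyclohexyl in place of oxan-4-yl on an amine nitrogen. Because every value sits at the limit of > 30000 nM in this assay, at which 3 of the 3 values shown sit, the change has not yet shown a readable effect. Compound 4 is expected around 30000 nM, estimated between 10000 nM and 100000 nM. The step of a number no higher from compound 3 to compound 4 (the limit leaves the size open) is expected to stay unreadable, resting on the paired limits of compound 1 and compound 2.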

Compound 4, half-maximal effective concentration: > 30000 nM
Compound 4 was reported as a limit (the forecaster's own chance of this, stated with the estimate: 85%); the middle value sits exactly at the limit.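

In this assay compound 4 gives > 30000 nM, a limit and not a number, and the step from compound 3 to compound 4 cannot be read. The compounds shown leave open whether 4,4-dimethylcyclohexyl in place of oxan-4-yl alters the read-out on either core.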